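The compounds below may be only part of what the source reports. "The series", "measured", "known", "first", "only" and "open" are said of these compounds alone.

Working notes on a small quinoxaline-sulfone series. Compound 1 `COc1cc(Nc2nc3ccccc3nc2S(=O)(=O)c2ccccc2)cc(OC)c1`, compound 2 `Nc1ccc(Nc2nc3ccccc3nc2S(=O)(=O)c2ccccc2)cc1` and compound 3 `COc1ccc(S(=O)(=O)c2nc3ccccc3nc2Nc2cc(OC)cc(OC)c2)cc1` have been tested in a functional assay on HCT-116 cells (Homo sapiens) for cytotoxicity, read by MTT assay, with a stated time of 72 h; a lower number here means a stronger inhibitor, a higher number a weaker inhibitor; compound 4 `COc1ccc(S(=O)(=O)c2nc3ccccc3nc2Nc2ccc(N)cc2)cc1` has not. In this assay compound 1 gives 950 nM, compound 2 gives 10800 nM and compound 3 gives 13400 nM. Two single changes start from compound 1. The first, (4-aminophenyl in place of 3,5-dimethoxyphenyl on a nitrogen on an aromatic ring), gave an 11-fold higher number from compound 1 to compound 2 (1.06 log units; beyond the scatter). The second, (methoxy in place of hydrogen on an aromatic carbon), gave a 14-fold higher number from compound 1 to compound 3 (1.15 log units; beyond the scatter). Compound 2 and compound 3 are within the scatter of each other.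

Compound 4 carries the same change, relative to compound 3, as compound 2 does relative to compound 1: 4-aminophenyl in place of 3,5-dimethoxyphenyl on a nitrogen on an aromatic ring. The place is the same word for word in both pairs, so this is the same change. The two cores differ only by methoxy in place of hydrogen on an aromatic carbon. On that basis the step from compound 3 to compound 4 is expected to be a 4.5-fold higher number from compound 3 to compound 4 (0.65 log units; beyond the scatter), resting on compound 1 to compound 2 having shown an 11-fold higher number from compound 1 to compound 2 (1.06 log units; beyond the scatter), though from a much weaker start and with a limit of the assay possible. Compound 4 is thus estimated at 60000 nM in this assay, between 20000 nM and 200000 nM.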

Compound 4, half-maximal inhibitory concentration: 6300 nM
Compound 4: the middle estimate sits 9.5-fold (0.98 log units) above what was measured; measured number outside the range, below it.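

In this assay, the change to 4-aminophenyl from 3,5-dimethoxyphenyl on the nitrogen does not carry over from the core of compound 1 to the methoxy-bearing core, where it gives a 2.1-fold lower number from compound 3 to compound 4 (0.33 log units; beyond the scatter), opposite in direction to the earlier step: the same change on two cores in this assay, an 11-fold higher number (1.06 log units; beyond the scatter) from compound 1 to compound 2 and a 2.1-fold lower number (0.33 log units; beyond the scatter) from compound 3 to compound 4, 24-fold (1.38 log units) apart, beyond the scatter of two such steps

The methoxy change likewise depends on the group on the nitrogen, as it gives a 1.7-fold lower number from compound 2 to compound 4 (0.23 log units; within the scatter), a step within the scatter, whereas it had a large effect with 3,5-dimethoxyphenyl: the same change on two cores in this assay, a 14-fold higher number (1.15 log units; beyond the scatter) from compound 1 to compound 3 and a 1.7-fold lower number (0.23 log units; within the scatter) from compound 2 to compound 4, 24-fold (1.38 log units) apart, beyond the scatter of two such steps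

So, within these four compounds, neither change has a single transferable effect, and a step measured on one core is a poor guide to the other; the data do not show why the two changes interact, or whether the same holds for any other groups.

Going by these compounds, it remains open whether a plain phenyl or a 4-hydroxyphenyl on the nitrogen would follow compound 1 or compound 3. Also open, on these data alone, is whether chlorine or an ethoxy group in place of the methoxy would give the same dependence on the group on the nitrogen.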